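Hydroxy to Amino Swap Carried onto a Second Core

The source may hold more compounds than are shown below. What is called first, only, known or untested is meant among the compounds shown, and "the series" means these compounds.

Three compounds have been measured in a functional assay on A549 cells (Homo sapiens) for antiproliferative activity, read by MTT assay, with a stated time of 48 h; a higher number here means a weaker inhibitor, a lower number a stronger inhibitor:

compound 1, `COc1ccc(C(=O)c2ccc3c(c2)C=CC(C)(C)O3)c(NC(=O)CO)c1`, gives 90 nM
compound 2, `COc1ccc(C(=O)c2ccc3c(c2)C=CC(C)(C)O3)c(NC(=O)CN)c1`, gives 310 nM
compound 3, `C=C(c1ccc(OC)cc1NC(=O)CO)c1ccc(OC)c2c1OC(C)(C)C=C2`, gives 40 nM

Compound 1 and compound 2 share one core and differ in a single place: amino in place of hydroxy on a saturated chain carbon bound to a carbonyl carbon. That change made a step of a 3.4-fold higher number from compound 1 to compound 2 (0.54 log units; beyond the scatter), a loss of potency beyond the scatter.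

Compound 3 stands lowest of the three numbers, with compound 1 nearest and compound 2 furthest from it. How the core of compound 3 differs from the core of compound 1 is not broken down here.

Compound 4, `C=C(c1ccc(OC)cc1NC(=O)CN)c1ccc(OC)c2c1OC(C)(C)C=C2`, is not yet measured. It differs from compound 3 in the same place, by the same change: amino in place of hydroxy on a saturated chain carbon bound to a carbonyl carbon. The place is worded identically for both pairs, so this is the same change on a different core.

Compound 4 is expected to follow the precedent, with a step of about a 3.3-fold higher number from compound 3 to compound 4 (0.51 log units; beyond the scatter), because the only shown instance of this change moved a 3.4-fold higher number from compound 1 to compound 2 (0.54 log units; beyond the scatter). The estimate for compound 4 in this assay is therefore 130 nM, with a likely range from 60 nM to 300 nM; the different core leaves room for the step to come out smaller or larger than the earlier one.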

Compound 4, half-maximal inhibitory concentration: 50 nM
For compound 4 the middle estimate is 2.6-fold (0.41 log units) above the measured one; measured number outside the range, below it.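

In this assay, among the compounds shown here, amino in place of hydroxy on a saturated chain carbon bound to a carbonyl carbon gives a 1.3-fold higher number from compound 3 to compound 4 (0.10 log units; within the scatter), so on the core of compound 3 the change makes no step that can be told from the scatter. Set beside the earlier step, the change does not carry over between the two cores at the same size: the same change on two cores in this assay, a 3.4-fold higher number (0.54 log units; beyond the scatter) from compound 1 to compound 2 and a 1.3-fold higher number (0.10 log units; within the scatter) from compound 3 to compound 4, 2.8-fold (0.44 log units) apart, beyond the scatter of two such steps. This shows that the loss seen on the core of compound 1 cannot be assumed on the core of compound 3, but with one pair on each core it does not show which feature of the cores separates the steps, or how the change would fare on a third core.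

The compounds shown leave open whether a dimethylamino group, a carboxylic acid or a longer chain such as aminoethyl in the same place would also separate the two cores. As far as these compounds go, it also remains open whether the gap between the steps would hold outside this assay.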